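Adding a methoxy to compound 3

This account rests on a few compounds, and the source may have more. Where it says the series, first, only, none or still open, it means among the compounds named here.

Of the compounds shown here, three built on one shared core have been tested in a functional assay on A549 cells (Homo sapiens) for antiproliferative activity, read by MTT assay, with a stated time of 48 h; on this read-out higher numbers stand for weaker inhibition and lower numbers for stronger inhibition. The first, compound 1 `c1ccc(-c2nn(-c3ccccc3)cc2-c2nc3ccccc3[nH]2)cc1`, gives 2710 nM. A bromo version, compound 2 `Brc1ccc2[nH]c(-c3cn(-c4ccccc4)nc3-c3ccccc3)nc2c1`, gives 1810 nM, and a fluoro version, compound 3 `Fc1ccc(-c2nn(-c3ccccc3)cc2-c2nc3ccccc3[nH]2)cc1`, gives 1510 nM. These three numbers all lie within the usual scatter of one another, so compound 3 cannot truly be ranked against the other two.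

The next compound is compound 4 `COc1ccc2[nH]c(-c3cn(-c4ccccc4)nc3-c3ccc(F)cc3)nc2c1`. It differs from compound 3 as follows: methoxy in place of hydrogen on an aromatic carbon. In words, this is methoxy in place of hydrogen on an aromatic carbon, in the carbon-only ring of the fused system.

Among the compounds with values here, two measured steps bear on this change, since each also replaces a hydrogen on an aromatic carbon. The bromo swap gave a 1.5-fold lower number from compound 1 to compound 2 (0.18 log units; within the scatter), and the fluoro swap gave a 1.8-fold lower number from compound 1 to compound 3 (0.25 log units; within the scatter). Within the data shown here, both are small, but neither involves a methoxy, and no measured compound carries one. The safest expectation is therefore no real shift in either direction. The expected change is a 1.1-fold lower number from compound 3 to compound 4 (0.03 log units; within the scatter), which would stay within the scatter. For compound 4 the estimated value is 1400 nM, with an expected range from 550 nM to 3500 nM.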

Compound 4, half-maximal inhibitory concentration: 1960 nM
Compound 4: middle estimate off by 1.4-fold (0.15 log units), on the low side, and the stated range covers the measured number.
By their numbers in this assay, from the lowest: compounds 3, 2, 4 and 1 (each within the scatter of the next).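

In this assay, putting methoxy in place of hydrogen on this aromatic carbon gives a 1.3-fold higher number from compound 3 to compound 4 (0.11 log units; within the scatter), so the step cannot be told apart from the ordinary spread of repeated measurements. Compound 4 is the only compound shown that carries two added groups, and it shows that this place on the six-membered ring of carbon only can hold methoxy, alongside the fluoro, with no readable loss of antiproliferative activity. No supporting measurement is available to say what lies behind this result.

Going by these compounds, a single group at one place cannot show how sensitive this position is, so it remains open whether an amine, a carboxylic acid or a longer chain such as butoxy would shift the number beyond the scatter in either direction. It is also open whether methoxy would behave the same way on the core of compound 1, without the fluoro, since the step shown here was read only with the fluoro in place.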